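Replacing the Aromatic Amide Group with an Oxane Ring

The source may hold more compounds than are shown below. What is called first, only, known or untested is meant among the compounds shown, and "the series" means these compounds.

Measured compounds:
- Compound 1, `CC(C)OC(=O)C1CN(C(=O)c2ccc(C#N)cc2)CC(C)(C)c2cc(C#N)[nH]c21`: 91%
- Compound 2, `CC(C)OC(=O)C1CN(C(=O)c2cccc(F)c2)CC(C)(C)c2cc(C#N)[nH]c21`: 84%

Both compounds share one core and differ only in the group attached to the amide carbonyl carbon. In an assay on HEK293 cells for agonist activity at Bile acid receptor (Homo sapiens), read by a luciferase reporter (on this read-out lower numbers stand for smaller maximal responses and higher numbers for larger maximal responses), compound 1 gives 91%, and compound 2 gives 84%. Compound 2 holds the lower of the two numbers, but the measured step is a number 7 percentage points lower from compound 1 to compound 2 (within the scatter), so the two values cannot be told apart.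

Compound 3, `CC(C)OC(=O)C1CN(C(=O)C2CCOCC2)CC(C)(C)c2cc(C#N)[nH]c21`, has not been measured. It differs from compound 2 in one place: oxan-4-yl in place of 3-fluorophenyl on a carbonyl carbon. For the measured compounds named here, the only measured step, a number 7 percentage points lower from compound 1 to compound 2 (within the scatter), swapped one six-membered aromatic ring for another and stayed inside the scatter. Going by the values given here, no measured step trades an aromatic ring for a non-aromatic, oxygen-containing ring, so that part of the change is untested. Among the compounds with values here, the one step available suggests the maximal response is not very sensitive to the group on this carbonyl carbon, and the expected step is a number 4 percentage points lower from compound 2 to compound 3 (within the scatter), which stays within the scatter. Compound 3 is therefore estimated to give 80% in this assay, within a range of 60% to 100%.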

Compound 3, largest response reached (reported as efficacy), in percent of the reference or control that the assay uses in the Bile acid receptor assay: 112%
Beside the measured number, compound 3's estimate is 32 percentage points below it; measured number outside the range, above it.
By their numbers in the Bile acid receptor assay, from the lowest: compounds 2 and 1 (each within the scatter of the next); then compound 3.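

In the Bile acid receptor assay the group on the carbonyl carbon turns out to matter: the oxan-4-yl ring, non-aromatic and holding one oxygen, brings a number 28 percentage points higher from compound 2 to compound 3 (beyond the scatter) and also a number 21 percentage points higher from compound 1 to compound 3 (beyond the scatter) and so sets compound 3 apart from the two aromatic amides, which could not be told apart from each other. In a physicochemical assay for solubility, at pH 7.4 (a lower number here means a less soluble compound, a higher number a more soluble compound), compound 2 gives > 100 ug/mL as a limit of the assay and not a number. In the physicochemical assay compound 3 gives > 100 ug/mL as a limit too, so the step between these two compounds cannot be read, and the change shows no readable effect on solubility: the limit of > 100 ug/mL in the physicochemical assay, at which 2 of the 2 values shown sit.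

The compounds shown do not separate the loss of the aromatic ring from the arrival of the ring oxygen, as the two happen together in this one change. A cyclohexyl group, the same ring with carbon in place of the oxygen, would pull these two apart, and a piperidin-4-yl group, with nitrogen in that place, would show whether the identity of that ring atom counts.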